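A few compounds are considered here, and "the series" means these few. Any claim that something is new, unique, unknown or untested is made for them only; others in the source may bear on it.

In a functional assay on OVCAR-3 cells (Homo sapiens) for antiproliferative activity, read by MTT assay, with a stated time of 24 h (on this read-out lower numbers stand for stronger inhibition and higher numbers for weaker inhibition), the compounds measured so far are:

Compound 1, `Cc1ccccc1-n1cc(-c2cccc(NS(=O)(=O)c3c[nH]c(=O)[nH]c3=O)c2)nn1`, gives 6230 nM.
Compound 2, `Cc1cccc(-n2cc(-c3cccc(NS(=O)(=O)c4c[nH]c(=O)[nH]c4=O)c3)nn2)c1`, gives 4080 nM.
Compound 3, `Cc1ccccc1-n1cc(-c2ccc(NS(=O)(=O)c3c[nH]c(=O)[nH]c3=O)cc2)nn1`, gives 7310 nM.

Compound 4, `Cc1cccc(-n2cc(-c3ccc(NS(=O)(=O)c4c[nH]c(=O)[nH]c4=O)cc3)nn2)c1`, has not yet been measured in this assay.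

Compound 1 and compound 2 differ in one place: 3-methylphenyl in place of 2-methylphenyl on an aromatic nitrogen. The step this change made is a 1.5-fold lower number from compound 1 to compound 2 (0.18 log units; within the scatter), so the two compounds cannot be told apart on this read-out. Compound 3 carries a different core from compound 1; the difference between the two cores is not broken down here. Compound 3 shows the highest of the three numbers, yet its gaps to compound 1 and to compound 2 are both within the scatter, so no order among the three can be read from these values.

Compound 4 stands to compound 3 as compound 2 stands to compound 1: 3-methylphenyl in place of 2-methylphenyl on an aromatic nitrogen. The place of the change is described in the same words in both cases, so this is the same change, now on the core of compound 3. Among the measured compounds shown here, only one earlier instance exists, so the expectation rests on that single step. Because the step of a 1.5-fold lower number from compound 1 to compound 2 (0.18 log units; within the scatter) lay within the scatter, compound 4 is expected to sit close to compound 3, with an expected step of a 1.5-fold lower number from compound 3 to compound 4 (0.17 log units; within the scatter). The estimate for compound 4 in this assay is therefore 4900 nM, most likely falling between 2500 nM and 9500 nM.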

Compound 4, half-maximal inhibitory concentration: 7490 nM
The estimate for compound 4 lay 1.5-fold (0.18 log units) below the measured number; low and high end bracket the measured number.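

In this assay putting 3-methylphenyl in place of 2-methylphenyl on the core of compound 3 gives a 1.0-fold higher number from compound 3 to compound 4 (0.01 log units; within the scatter) and so leaves the two compounds indistinguishable, as was already the case for the same change on the core of compound 1. What this does not show is that the two methylphenyl groups are equivalent in general: the read-out cannot separate small real differences from scatter, and two cores are a narrow base for any rule about this series. What it does show is that, on these two cores, the change gives no sign of behaving differently from one core to the other, since the two steps cannot be told apart: the same change on two cores in this assay, a 1.5-fold lower number (0.18 log units; within the scatter) from compound 1 to compound 2 and a 1.0-fold higher number (0.01 log units; within the scatter) from compound 3 to compound 4, 1.6-fold (0.19 log units) apart, within the scatter of two such steps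

The compounds shown leave open what happens when the aromatic nitrogen of the five-membered ring carries something other than these two methylphenyl groups, such as a plain phenyl, a benzyl or a longer alkyl chain. They also leave open whether a group carrying an amine or a carboxylic acid on that benzene ring would produce a step large enough to stand clear of the scatter on either core.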